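The source may report more compounds than this note shows. Statements on the series, on what has been measured and on what is new or still open speak of the compounds shown alone.

Measured so far in a functional assay on MGC-803 cells (Homo sapiens) for antiproliferative activity, read by MTT assay, with a stated time of 48 h; on this read-out higher numbers stand for weaker inhibition and lower numbers for stronger inhibition:
Compound 1 `COc1ccc2nc(SCC(=O)N(Cc3ccc(OC)c(O)c3)c3cc(OC)c(OC)c(OC)c3)sc2c1` gives 71 nM.
Compound 2 `COc1ccc(CN(C(=O)CSc2nc3ccccc3s2)c2cc(OC)c(OC)c(OC)c2)cc1F` gives 416 nM.

Within the data shown here, of the two numbers known in this assay, compound 2 stands at the highest; its nearest neighbour, compound 1, sits at a lower number, and that gap lies beyond the usual scatter of repeated measurements. Among the measured compounds shown here, no step between two measured compounds differing in a single place is available, so what a single change does here is not yet known.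

Compound 3 `COc1cc(N(Cc2ccc(F)cc2)C(=O)CSc2nc3ccccc3s2)cc(OC)c1OC` is the next compound to be measured in this assay. It differs from compound 2 in one place: 4-fluorophenyl in place of 3-fluoro-4-methoxyphenyl on a saturated chain carbon bound to an amide-type nitrogen. The change removes a methoxy substituent from the ring that stands on a saturated chain carbon bound to an amide-type nitrogen, and nothing else in the molecule moves.

Given that the only comparison at hand is the gap between compound 2 and compound 1, and that compound 1 with its 3-hydroxy-4-methoxybenzyl group shows 71 nM, compound 3 is expected to come out near compound 2 or a little weaker, with a step of a 1.4-fold higher number from compound 2 to compound 3 (0.16 log units; within the scatter) expected. The estimate for compound 3 is 600 nM, with a range from 250 nM to 1500 nM.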

Compound 3, half-maximal inhibitory concentration: > 80000 nM
Compound 3: only a limit was reported; the forecaster's own chance of this, stated with the estimate: 5%; middle value at least 130-fold (2.12 log units) from the limit.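

In this assay, among these compounds, this is the first change in a single place, and it shows that the group on a saturated chain carbon bound to an amide-type nitrogen is far from indifferent: 4-fluorophenyl in place of 3-fluoro-4-methoxyphenyl gives an at least 190-fold higher number from compound 2 to compound 3 (2.28 log units; beyond the scatter). Compound 2 keeps measurable inhibition with 3-fluoro-4-methoxyphenyl at this place, so the whole loss comes from one change to that ring, with the rest of the molecule unchanged. On these data alone, for compound 3 the reading is a limit and not a number, so the step fixes only a minimum size and the true distance stays unknown: the limit of > 80000 nM in this assay, at which 1 of the 3 values shown sits.

The two groups differ in more than the methoxy, since the names also place the fluorine differently, so the compounds shown cannot say whether the loss follows the missing methoxy or the fluorine, and a 4-methoxyphenyl or a 3-fluorophenyl group at this place would separate the two. Why the change costs so much also stays open, as does whether a larger ethoxy group would serve in place of the methoxy or whether the same step would appear on the core of compound 1.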